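Amine swap on the benzylic position of compound 2

The compounds below may be only part of what the source reports. "The series", "measured", "known", "first", "only" and "open" are said of these compounds alone.

Measured so far in an assay on CHO cells for antagonist activity at melanin-concentrating hormone receptor 1 (Homo sapiens), read by luminescence and calcium flux, with a stated time of 10 min; on this read-out higher numbers stand for weaker inhibition and lower numbers for stronger inhibition:
compound 1 `COc1ccc([C@@H](C)NC(=O)c2ccc(CC3CCN(Cc4ccc5ccccc5c4)CC3)cc2)cc1` gives 40 nM
compound 2 `CN1CCN(CCCN(c2nc3cc(F)c(F)cc3[nH]2)[C@@H]2CC[C@]3(c4cccc(CN5CCCCC5)c4)C[C@@H]3C2)CC1` gives 405 nM

Compound 2 carries the highest of the two numbers; compound 1 sits well apart from it, beyond the scatter. Compound 3 `CN1CCN(CCCN(c2nc3cc(F)c(F)cc3[nH]2)[C@@H]2CC[C@]3(c4cccc(CN5CCC[C@H]5CO)c4)C[C@@H]3C2)CC1` is not yet measured. It differs from compound 2 by 2-(hydroxymethyl)pyrrolidin-1-yl in place of piperidin-1-yl on a saturated chain carbon bound to an aromatic carbon. For the measured compounds named here, no pair of measured compounds isolates such a change, so there is no basis for a step in either direction; none beyond the scatter is expected. The step from compound 2 to compound 3 is estimated as a 1.2-fold lower number from compound 2 to compound 3 (0.06 log units; within the scatter). Compound 3 is expected near 350 nM, with a range from 100 nM to 1200 nM.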

Compound 3, half-maximal inhibitory concentration: 3000 nM
For compound 3 the middle estimate is 8.6-fold (0.93 log units) below the measured one; measured number above the stated range.
By their numbers in this assay, from the lowest: compound 1; then compound 2; then compound 3.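

In this assay, the amine on a saturated chain carbon bound to an aromatic carbon is not a silent position: 2-(hydroxymethyl)pyrrolidin-1-yl in place of piperidin-1-yl gives a 7.4-fold higher number from compound 2 to compound 3 (0.87 log units; beyond the scatter), towards weaker inhibition. For the compounds shown here, this is the first single-place change. Nothing available accounts for the loss.
The swap alters ring size and adds the hydroxymethyl at once, so the compounds shown do not separate these two changes; plain pyrrolidin-1-yl or 4-hydroxypiperidin-1-yl would. Going by these compounds, the opposite configuration of the hydroxymethyl-bearing carbon also remains open.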